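Swapping the anilide aryl group on a short-chain triazole thioether

This account rests on a few compounds, and the source may have more. Where it says the series, first, only, none or still open, it means among the compounds named here.

Measured so far:
compound 1, `Cn1c(Cc2nn(C)c(=O)c3ccccc23)nnc1SCCCCCCCC(=O)Nc1ccc(F)cc1F`: 2300 nM
compound 2, `CCCOc1ccc(NC(=O)CSc2nnc(Cc3nn(C)c(=O)c4ccccc34)n2C)cc1`: > 30000 nM

Two compounds share a core and differ in the chain that links the thioether to an anilide and in the aryl group on that anilide. In an assay on isolated protein (Mus musculus) for inhibition of IL15-IL15 receptor (Homo sapiens), read by resazurin assay, with stated times of 30 min and 2.5 days (on this read-out lower numbers stand for stronger inhibition and higher numbers for weaker inhibition), compound 1 gives 2300 nM. Compound 2 gives only a limit of the assay, > 30000 nM, so its true potency is not pinned down by a number; this is the situation summed up in the limit of > 30000 nM in this assay, at which 1 of the 2 values shown sits.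

Compound 3, `Cn1c(Cc2nn(C)c(=O)c3ccccc23)nnc1SCC(=O)Nc1ccc(Br)cc1Br`, keeps the short chain of compound 2 and differs from it in one place: 2,4-dibromophenyl in place of 4-propoxyphenyl on an amide-type nitrogen. Among the measured compounds shown here, no measured step of this kind exists here, so the direction has to be guessed. Compound 3 is expected to move modestly toward stronger inhibition, by an at least 2.0-fold lower number from compound 2 to compound 3 (0.30 log units; that floor lies within the scatter), because compound 1, which also carries two halogens on its anilide ring, gives 2300 nM. Compound 3 is therefore estimated at 15000 nM, somewhere between 4000 nM and 40000 nM.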

Compound 3, half-maximal inhibitory concentration: > 30000 nM
Compound 3 ended at the assay's limit (the forecaster's own chance of this, stated with the estimate: 45%); middle value at least 2.0-fold (0.30 log units) from the limit.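

No step from compound 2 to compound 3 can be read, because each compound gives a limit of the assay and not a number: the limit of > 30000 nM in this assay, at which 2 of the 3 values shown sit.

The compounds shown leave open whether 2,4-dibromophenyl or 4-propoxyphenyl gives stronger inhibition on this short chain.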